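One Stereocentre Redrawn in a Stable Pair

The source may hold more compounds than are shown below. What is called first, only, known or untested is meant among the compounds shown, and "the series" means these compounds.

In an ADME assay on microsomes from liver (Homo sapiens) for metabolic stability, using NADPH, with a stated time of 10 min (on this read-out higher numbers stand for a more stable compound and lower numbers for a less stable compound), compound 1 `NCCCCN(C[C@H]1Cc2ncccc2CN1)[C@H]1CCCc2cccnc21` gives 100% and compound 2 `NCCCCN(C[C@H]1Cc2cccnc2CN1)[C@H]1CCCc2cccnc21` gives 96%, so these two values lie within the usual scatter of each other. Compound 3 `NCCCCN(C[C@@H]1Cc2cccnc2CN1)[C@H]1CCCc2cccnc21` has the same atoms and bonds as compound 2 the two compounds have the same atoms and bonds and differ only in configuration as drawn: 1 of 2 stereo elements differ; a stereocentre at a saturated ring carbon is drawn R in compound 2 and S in compound 3: a stereocentre at a saturated ring carbon is drawn R in compound 2 and S in compound 3. Within the data shown here, no measured pair yet shows what such a change does, so no shift beyond the scatter is expected. The expected step is small, slightly downward, a number 3 percentage points lower from compound 2 to compound 3 (within the scatter). For compound 3 the estimated value is 93%, with an expected range of 80% to 100%.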

Compound 3, percent of the compound remaining: 92%
Beside the measured number, compound 3's estimate is 1 percentage points above it; the range from low to high includes it.
By their numbers in this assay, from the lowest: compounds 3, 2 and 1 (each within the scatter of the next).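

In this assay, redrawing a stereocentre at a saturated ring carbon from R to S gives a number 4 percentage points lower from compound 2 to compound 3 (within the scatter) and so no change that stands clear of the scatter. For this pair, the configuration drawn at this carbon makes no measurable difference to stability on this read-out. The comparison isolates that single feature: the fact that compounds 2 and 3 differ only in the configuration as drawn.

On these data alone, the other stereocentre is drawn the same in compound 2 and compound 3, so its effect remains open. Also open, as far as these compounds go, is how a compound with a carboxylic acid in place of the amine would behave.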